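From methyl to phenyl in a cell toxicity test

The source may report more compounds than this note shows. Statements on the series, on what has been measured and on what is new or still open speak of the compounds shown alone.

Compound 1 `C/C(=N\Nc1nc(C)cs1)c1ccc(Cl)c(Cl)c1` gives 33700 nM
Compound 2 `C/C(=N\Nc1nc(C)c(C)s1)c1ccc(Cl)c(Cl)c1` gives 41800 nM
Compound 3 `C/C(=N\N=c1\scc(-c2ccccc2)n1C)c1ccc(Cl)c(Cl)c1` gives > 50000 nM as a limit of the assay

In an ADME assay on J774 cells (Mus musculus) for cytotoxicity, read by resazurin assay, with a stated time of 72 h (on this read-out lower numbers stand for higher toxicity in this test and higher numbers for lower toxicity in this test), compound 2 (41800 nM) lies within the scatter of compound 1 (33700 nM). Compound 3 gives > 50000 nM as a limit and not as a number. Compound 4 `C/C(=N\Nc1nc(-c2ccccc2)c(C)s1)c1ccc(Cl)c(Cl)c1` carries phenyl in place of methyl on an aromatic carbon and awaits measurement. Among the measured compounds shown here, one measured step bears on this change (a 1.2-fold higher number from compound 1 to compound 2 (0.09 log units; within the scatter)). It put methyl in place of hydrogen and stayed within the scatter, but phenyl is a larger group, so it is only a weak guide. No step beyond the scatter is expected (a 1.3-fold lower number from compound 2 to compound 4 (0.12 log units; within the scatter)). Compound 4 is estimated at 32000 nM (range 12000 nM to 50000 nM).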

Compound 4, half-maximal cytotoxic concentration: > 50000 nM
Compound 4 ended at the assay's limit; the forecaster's own chance of this, stated with the estimate: 30%; middle value at least 1.5-fold (0.19 log units) from the limit.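

The earlier step changed a different ring carbon, so this is the first change shown at the carbon next to the ring nitrogen, and the larger phenyl brings no lower number in this assay: the step is an at least 1.1-fold higher number from compound 2 to compound 4 (0.07 log units; that floor lies within the scatter). Compound 4 gives > 50000 nM, which is a limit of the assay and not a number. The full size of the step cannot be read because the measurement stops there: the limit of > 50000 nM in this assay, at which 2 of the 4 values shown sit.

Still open, from the compounds shown here alone, is whether an amine or a carboxylic acid at this position would give a number within the measurable range.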